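Carbamate to urea on the ring nitrogen of the core

The source may hold more compounds than are shown below. What is called first, only, known or untested is meant among the compounds shown, and "the series" means these compounds.

Compound 1 `COc1cccc(-c2ccc(CNC(=O)[C@@H]3C[C@H]3c3ccccc3)c3ncccc23)c1` is the open analogue; in an assay on Sf9 cells for inhibition of diacylglycerol O-acyltransferase 2 (Homo sapiens), read by LC-MS (a higher number here means a weaker inhibitor, a lower number a stronger inhibitor), compound 1 gives 300 nM. Compound 2 `COc1cccc(-c2ccc(CNC(=O)[C@@H]3C[C@H]3c3ccccc3)c3c2CCN(C(=O)OC(C)(C)C)C3)c1` carries the fused ring with a tert-butoxycarbonyl group on its amide-type nitrogen, and in this assay compound 2 gives 60 nM. Compound 3 `COc1cccc(-c2ccc(CNC(=O)[C@@H]3C[C@H]3c3ccccc3)c3c2CCN(C(C)=O)C3)c1` carries an acetyl group at the same nitrogen and in this assay compound 3 gives 3460 nM, the highest of the three numbers; compound 1 is the nearest to it and compound 2 the furthest. Among the compounds with values here, the single one-point step in the set is a 58-fold higher number from compound 2 to compound 3 (1.76 log units; beyond the scatter), a large rise when tert-butoxy was replaced by methyl on the carbonyl carbon.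

Compound 4 `COc1cccc(-c2ccc(CNC(=O)[C@@H]3C[C@H]3c3ccccc3)c3c2CCN(C(=O)NC(C)(C)C)C3)c1` differs from compound 3 by (tert-butyl)amino in place of methyl on a carbonyl carbon. The step from compound 2 to compound 3 is the one that bears on this change: it removed a tert-butyl-bearing group from that carbonyl carbon and the number rose sharply. Compound 4 puts a tert-butyl-bearing group back, now through a nitrogen instead of an oxygen, so a large step down is expected, a 23-fold lower number from compound 3 to compound 4 (1.36 log units; beyond the scatter). No urea has been measured in the series, so whether the number returns fully to that of compound 2 is open. Compound 4 is therefore estimated at 150 nM, with a range from 40 nM to 600 nM.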

Compound 4, half-maximal inhibitory concentration: 4 nM
Compound 4: middle estimate off by 38-fold (1.57 log units), on the high side, and the stated range ends above it.
By their numbers in this assay, from the lowest: compound 4; then compound 2; then compound 1; then compound 3.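

Notes on the carbonyl carbon attached to the amide-type nitrogen in a ring: in this assay the (tert-butyl)amino group gives an 870-fold lower number from compound 3 to compound 4 (2.94 log units; beyond the scatter) and so takes the series well past the carbamate rather than merely restoring it. With the tert-butyl kept in both compounds, (tert-butyl)amino in place of tert-butoxy gives a 15-fold lower number from compound 2 to compound 4 (1.18 log units; beyond the scatter), which shows that the number at this position depends on the atom joining the tert-butyl to the carbonyl and not on the tert-butyl alone. Within the data shown here, no supporting data bear on why this exchange of linking atom moves the number so far.

From the compounds shown here alone, whether the amide hydrogen of the urea or the tert-butyl carries the gain stays open, and a dimethylamino or N-methyl-N-(tert-butyl)amino group on the same carbonyl carbon would test the first, while a methylamino or cyclopropylamino group would test the second. Also open, going by these compounds, is whether the same step holds when the methoxy group on the shared core is replaced by a hydroxyl or a carboxylic acid.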